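Benzyloxy variation on the acylurea core: compound 4

This account rests on a few compounds, and the source may have more. Where it says the series, first, only, none or still open, it means among the compounds named here.

Going by the values given here, compound 3 `Cc1ccc(NC(=O)NC(=O)c2ccc(OCc3ccccc3F)cc2)cc1-c1nc2ccccc2[nH]1` carries the (2-fluorobenzyl)oxy group on the shared core, and in a functional assay on HT-29 cells (Homo sapiens) for inhibition, read by MTT assay, with a stated time of 48 h (on this read-out lower numbers stand for stronger inhibition and higher numbers for weaker inhibition), compound 3 gives 760 nM, the lowest of the three numbers measured so far. Compound 2 `Cc1ccc(NC(=O)NC(=O)c2ccc(OCc3cccc(Cl)c3)cc2)cc1-c1nc2ccccc2[nH]1`, the 3-chlorophenyl analogue, gives 15400 nM in this assay, and compound 1 `Cc1ccc(NC(=S)NC(=O)c2ccc(OCc3cccc(Cl)c3)cc2)cc1-c1nc2ccccc2[nH]1`, which carries a thiourea in place of the urea of the other two, gives 35300 nM. Among the compounds with values here, the step of a 20-fold lower number from compound 2 to compound 3 (1.31 log units; beyond the scatter) is the only single-site change measured and it is large and well beyond the scatter. Within the data shown here, no single-site step joins compound 1 to compound 3.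

Compound 4 `Cc1ccc(NC(=O)NC(=O)c2ccc(OCc3ccc(Cl)c(Cl)c3)cc2)cc1-c1nc2ccccc2[nH]1` differs from compound 3 by 3,4-dichlorophenyl in place of 2-fluorophenyl on a saturated chain carbon bound to an oxygen on an aromatic ring. The change puts chlorine back onto the ring whose chlorine-bearing form, compound 2, went with the far higher number, and adds a second chlorine on the same ring. The measured step from compound 2 to compound 3 ran in the favourable direction. The present change runs the other way on the same ring, so a step back upward is expected, estimated at an 11-fold higher number from compound 3 to compound 4 (1.02 log units; beyond the scatter). What the second chlorine adds is not shown by any measured pair, which widens the range. Compound 4 is therefore expected to give about 8000 nM in this assay, with a range of 1500 nM to 40000 nM.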

Compound 4, half-maximal inhibitory concentration: 1030 nM
Estimate against measurement, compound 4: 7.8-fold (0.89 log units) above, and the stated range ends above it.
By their numbers in this assay, from the lowest: compounds 3 and 4 (each within the scatter of the next); then compound 2; then compound 1.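

The fluorine-bearing and dichlorinated rings sit close together here: the change on the saturated chain carbon gives a 1.4-fold higher number from compound 3 to compound 4 (0.13 log units; within the scatter) in this assay and so leaves no readable difference between the 2-fluorophenyl and the 3,4-dichlorophenyl groups. Chlorine on this ring is therefore not tied to the high numbers, and the high number of compound 2 belongs to the 3-chlorophenyl group specifically rather than to chlorine in general, with compound 2 the one chlorine-bearing urea that goes against the low numbers of the other two. The single added chloro in place of hydrogen on an aromatic carbon accounts for a 15-fold lower number from compound 2 to compound 4 (1.17 log units; beyond the scatter) and is as large as the step that fluorine gave, yet nothing available explains why one added chlorine has so much weight.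

Open, going by these compounds, is how an unsubstituted phenyl, a pyridine ring or a trifluoromethyl-bearing phenyl would read on the same chain carbon, which would show whether the high number of compound 2 is the exception. Also open, on these data alone, is whether the thiourea of compound 1 would follow the same course when paired with the 3,4-dichlorophenyl or 2-fluorophenyl groups.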